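Swapping a Sulfonyl for a Sulfonimidoyl on a Cell-Growth Inhibitor

The source may hold more compounds than are shown below. What is called first, only, known or untested is meant among the compounds shown, and "the series" means these compounds.

compound 1, `CCCN(CCC)S(=O)(=O)c1ccc(S(=O)(=O)N2CCC[C@@H](C(=O)OCC)C2)cc1`, in a functional assay on MIA PaCa-2 cells (Homo sapiens) for inhibition, read by MTT assay, with a stated time of 3 days (a higher number here means a weaker inhibitor, a lower number a stronger inhibitor), gives 600 nM
compound 2, `CCOC(=O)[C@@H]1CCCN(S(=O)(=O)c2ccc(S(=O)(=O)N3CCCCC3)cc2)C1`, in this assay gives 1000 nM

Compound 2 stands within the scatter of compound 1: the step of a 1.7-fold higher number from compound 1 to compound 2 (0.22 log units; within the scatter) is too small to rank the two. Compound 3, `CCOC(=O)[C@@H]1CCCN(S(=O)(=O)c2ccc(S(=N)(=O)N(CC)CC)cc2)C1`, differs from compound 2 by a group of 8 heavy atoms (4 carbon, 2 nitrogen, 1 oxygen, 1 sulfur; no ring) in place of a group of 9 heavy atoms (5 carbon, 1 nitrogen, 2 oxygen, 1 sulfur; one six-membered non-aromatic ring with 1 hetero atom), on an aromatic carbon. For the measured compounds named here, the only measured step changes the amine on that same sulfur and stays within the scatter, but no measured step exchanges an oxygen on the sulfur for nitrogen, so the expectation rests on little. Compound 3 is therefore expected near 900 nM (range 250 nM to 3500 nM), estimated as a step of a 1.1-fold lower number from compound 2 to compound 3 (0.05 log units; within the scatter) that need not exceed the scatter.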

Compound 3, half-maximal inhibitory concentration: 900 nM
For compound 3 middle estimate and measured number coincide at the digits printed; low and high end bracket the measured number.
By their numbers in this assay, from the lowest: compounds 1, 3 and 2 (each within the scatter of the next).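

Compound 3 shows that this aromatic carbon tolerates a larger change than the swap of one amine for another: one oxygen on the sulfur is exchanged for nitrogen, and the group gains a hydrogen-bond donor. Yet this assay shows only a 1.1-fold lower number from compound 2 to compound 3 (0.05 log units; within the scatter), and likewise a 1.5-fold higher number from compound 1 to compound 3 (0.18 log units; within the scatter), so no effect can be read from either step. Nothing available here bears on this result.

Compound 3 changes the sulfur and the amine together, so a diethylamino sulfonyl compound would be needed to separate them. From the compounds shown here alone, a methyl on the new nitrogen remains open too.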